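The source may report more compounds than this note shows. Statements on the series, on what has been measured and on what is new or still open speak of the compounds shown alone.

Compound 1: `CC(=O)NCC[C@@H]1C[C@@H](c2ccc(F)c(F)c2)[C@H](NC(=O)c2cc(-c3c(Cl)cnn3C)c(Cl)o2)CN1` — 130 nM
Compound 2: `Cn1ncc(Cl)c1-c1cc(C(=O)N[C@@H]2CN[C@H](CCO)C[C@H]2c2ccc(F)c(F)c2)oc1Cl` — 60 nM
Compound 3: `Cn1ncc(Cl)c1-c1cc(C(=O)N[C@@H]2CN[C@H](CCN3CCCC3)C[C@H]2c2ccc(Cl)c(Cl)c2)oc1Cl` — 1920 nM

In a functional assay on LNCaP cells (Homo sapiens) for antiproliferative activity (on this read-out higher numbers stand for weaker inhibition and lower numbers for stronger inhibition), compound 3 gives 1920 nM, the highest number of the three; compound 1 gives 130 nM and compound 2 gives 60 nM, and both gaps from compound 3 lie beyond the scatter. Compound 4 is `CNC(=O)C[C@@H]1C[C@@H](c2ccc(Cl)c(Cl)c2)[C@H](NC(=O)c2cc(-c3c(Cl)cnn3C)c(Cl)o2)CN1`. Its change from compound 3 is methylcarbamoyl in place of (pyrrolidin-1-yl)methyl on a saturated chain carbon bound to a saturated ring carbon. Within the data shown here, the only measured step, a 2.2-fold lower number from compound 1 to compound 2 (0.34 log units; beyond the scatter), concerns a different terminus on a chain that is otherwise built the same way, and it is modest; no measured pair changes the side chain of compound 3 or separates its dichlorophenyl from the difluorophenyl of compound 1 and compound 2. Compound 1, which carries an amide at its chain end, gives 130 nM, and this is the nearest reference for an amide-bearing chain. On that basis compound 4 is expected to give a lower number than compound 3, a 4.8-fold lower number from compound 3 to compound 4 (0.68 log units; beyond the scatter), with wide uncertainty. The estimate for compound 4 is 400 nM, in the range 100 nM to 1600 nM.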

Compound 4, half-maximal inhibitory concentration: 40 nM
For compound 4 the middle estimate is 10-fold (1.00 log units) above the measured one; measured number outside the range, below it.
By their numbers in this assay, from the lowest: compounds 4 and 2 (each within the scatter of the next); then compound 1; then compound 3.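

In this assay, among these compounds, the group on a saturated chain carbon bound to a saturated ring carbon carries far more weight than the one earlier step suggested: with everything else held fixed, methylcarbamoyl in place of (pyrrolidin-1-yl)methyl gives a 48-fold lower number from compound 3 to compound 4 (1.68 log units; beyond the scatter), against the modest 2.2-fold lower number from compound 1 to compound 2 (0.34 log units; beyond the scatter). The dichlorophenyl alone does not hold the number high, as compound 4 carries it and gives 40 nM. No measurement here accounts for the size of this step.

The compounds shown do not separate the contributions of the pyrrolidine ring, the amide and the chain length to this step. On these data alone, how a dimethylamino group or a carboxylic acid would read in this place remains open, as does whether dichlorophenyl and difluorophenyl behave alike on one and the same side chain.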